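A few compounds are considered here, and "the series" means these few. Any claim that something is new, unique, unknown or untested is made for them only; others in the source may bear on it.

Measured compounds:
compound 1 `Cc1ccc2[nH]c(-n3cccn3)c(C3=C(Br)C(=O)NC3=O)c2c1` — 27000 nM
compound 2 `Cc1ccc2[nH]c3c4cn[nH]c4c4c(c3c2c1)C(=O)NC4=O` — > 100000 nM
compound 3 `O=C1NC(=O)c2c1c1[nH]ncc1c1[nH]c3ccccc3c21` — > 100000 nM

Going by the values given here, in a functional assay on U-373MG ATCC cells (Homo sapiens) for cytotoxicity, read by MTT assay, with a stated time of 72 h (a higher number here means a weaker inhibitor, a lower number a stronger inhibitor), compound 1 gives 27000 nM, the only plain number among the three. For compound 2 the value > 100000 nM is a limit of the assay, not a number. For compound 3 the value > 100000 nM is likewise a limit. The change from compound 2 to compound 3 is hydrogen in place of methyl on an aromatic carbon, and its step that the two limits leave unreadable from compound 2 to compound 3 cannot be sized because of the limit of > 100000 nM in this assay, at which 2 of the 3 values shown sit.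

Compound 4 `O=C1NC(=O)C(c2c(-n3cccn3)[nH]c3ccccc23)=C1Br` differs from compound 1 by hydrogen in place of methyl on an aromatic carbon. This is the same kind of change, though the place differs: in compound 2 and compound 3 the ring is part of a fused or bridged system of five rings, in compound 1 and compound 4 of two rings. The difference between the cores of compound 1 and compound 2 is not broken down here.

Among the compounds with values here, the only measured instance of this change gives no readable size, so the expectation for compound 4 rests on compound 1's value 27000 nM and on the smallness of the change; the expected step is a 1.3-fold higher number from compound 1 to compound 4 (0.11 log units; within the scatter), within the usual scatter. Compound 4 is estimated at 35000 nM, between 12000 nM and 100000 nM.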

Compound 4, half-maximal inhibitory concentration: 27000 nM
Estimate against measurement, compound 4: 1.3-fold (0.11 log units) above, within the range that was stated.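

In this assay, hydrogen in place of methyl on the aromatic carbon gives no change at the digits printed from compound 1 to compound 4 (within the scatter), so on this core the methyl group makes no readable difference. Going by these compounds alone, this does not show that the change behaves the same way on both cores, since this is the only pair that can be read, and one pair sets no rule for the series. The step from compound 2 to compound 3, the same kind of change on the other core, cannot be read because both compounds sit at a limit of the assay rather than at a number: the limit of > 100000 nM in this assay, at which 2 of the 4 values shown sit.

The compounds shown leave open whether a different group at this place on the core of compound 1, such as an amine, a carboxylic acid or a longer chain, would shift the value in this assay. They also leave open whether any change to the core of compound 2 would give a value that can be read as a number.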